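Extending the Ether Chain on a Very Tight Binder

The compounds below may be only part of what the source reports. "The series", "measured", "known", "first", "only" and "open" are said of these compounds alone.

Compound 3 `CCCOc1cncc(N2C[C@H]3CNC[C@H]3C2)c1` has the lowest number of the three compounds measured in an assay on membranes from brain for displacement of a labelled ligand from Neuronal acetylcholine receptor; alpha4/beta2 (Rattus norvegicus); on this read-out higher numbers stand for weaker inhibition and lower numbers for stronger inhibition: compound 3 gives 0.041 nM. Its nearest neighbour is compound 2 `Brc1cncc(N2C[C@H]3CNC[C@H]3C2)c1`, which gives 0.06 nM, while compound 1 `c1cncc(N2C[C@H]3CNC[C@H]3C2)c1`, which gives 0.12 nM, stands furthest away. The step of a 2.9-fold lower number from compound 1 to compound 3 (0.47 log units; beyond the scatter) is modest but beyond the scatter, whereas a 1.5-fold lower number from compound 2 to compound 3 (0.17 log units; within the scatter) and a 2.0-fold lower number from compound 1 to compound 2 (0.30 log units; within the scatter) both lie within it.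

Compound 4 `c1ccc(COc2cncc(N3C[C@H]4CNC[C@H]4C3)c2)cc1` keeps the ether oxygen and alters only the far end of the chain: phenyl in place of ethyl on a saturated chain carbon bound to an oxygen on an aromatic ring. Among the compounds with values here, no measured step tests a change of this kind. Within the data shown here, the steps that bear on it, a 2.9-fold lower number from compound 1 to compound 3 (0.47 log units; beyond the scatter) and a 1.5-fold lower number from compound 2 to compound 3 (0.17 log units; within the scatter), show only that the propoxy group at this position gives a somewhat lower number than hydrogen or bromo. With the chain merely carried further out, compound 4 is expected to stay close to compound 3, with an estimated step of a 1.2-fold higher number from compound 3 to compound 4 (0.09 log units; within the scatter) in this assay. The value estimated for compound 4 is 0.05 nM, with a likely range from 0.015 nM to 0.2 nM.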

Compound 4, inhibition constant: 0.058 nM
For compound 4 the middle estimate is 1.2-fold (0.06 log units) below the measured one; the measured number falls inside the stated range.
By their numbers in this assay, from the lowest: compounds 3, 4, 2 and 1 (each within the scatter of the next, the first and the last beyond it).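

In this assay the swap of ethyl for phenyl on a saturated chain carbon bound to an oxygen on an aromatic ring gives a 1.4-fold higher number from compound 3 to compound 4 (0.15 log units; within the scatter) and so leaves compound 3 and compound 4 indistinguishable. The earlier compounds shown here compared only groups placed directly on the aromatic carbon, whereas this pair shows that the far end of the ether chain can go from propyl to benzyl, gaining a whole aromatic ring, with no change beyond the scatter. Nothing available here explains why the number holds.

Within the data shown here, only this one ring-bearing ether has been compared with propoxy, so it remains open whether a longer chain ending in phenyl would behave the same way. It is also unknown whether an amine or a carboxylic acid at the end of the chain would leave the number as undisturbed.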